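Swapping the Saturated Ring on a Shared Core

This account rests on a few compounds, and the source may have more. Where it says the series, first, only, none or still open, it means among the compounds named here.

Of the compounds shown here, two sharing one core have been measured in a physicochemical assay for solubility, using the shake flask method, measured as kinetic solubility, with a stated time of 20 h, at pH 2; on this read-out lower numbers stand for lower solubility and higher numbers for higher solubility. Compound 1, `COc1ccnc(Nc2cc3[nH]c(-c4cccc(C(F)(F)F)c4)nc3cn2)c1`, gives in this assay only a limit, < 5000 nM. Among the compounds with values here, compound 2, `FC(F)(F)c1ccc(Nc2cc3[nH]c(C4CCCC4)nc3cn2)nc1`, gives 132000 nM in this assay, the single real number among the two results. The result of compound 1 is a limit, as the limit of < 5000 nM in this assay, at which 1 of the 2 values shown sits, shows. Compound 3, `FC(F)(F)c1ccc(Nc2cc3[nH]c([C@H]4CC[C@H](C(F)(F)F)CC4)nc3cn2)nc1`, has not yet been measured. It differs from compound 2 in one place: 4-(trifluoromethyl)cyclohexyl in place of cyclopentyl on an aromatic carbon. The entering group sits on an aromatic carbon of a five-membered aromatic ring with two nitrogen, part of a fused or bridged system of two rings, between two ring nitrogen atoms. Within the data shown here, no pair of measured compounds shows this same exchange, so no measured step can be pointed to. The expectation is nonetheless a fall in solubility from compound 2 to compound 3 of a 4.4-fold lower number from compound 2 to compound 3 (0.64 log units; beyond the scatter), a step beyond the usual scatter. Compound 3 is therefore expected to give about 30000 nM in this assay, with a likely range from 6000 nM to 120000 nM.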

Compound 3, solubility: 200000 nM
Beside the measured number, compound 3's estimate is 6.7-fold (0.82 log units) below it; the whole stated range lies below it.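

In this assay, putting 4-(trifluoromethyl)cyclohexyl in place of cyclopentyl on this aromatic carbon, between two ring nitrogen atoms, gives a 1.5-fold higher number from compound 2 to compound 3 (0.18 log units; within the scatter). Within the data shown here, this is the first measured one-place step, and it shows that, on this core and in this read-out, the position accepts a saturated ring of 10 heavy atoms, 3 of them fluorine, in place of one of 5 heavy atoms, with the two results indistinguishable within the usual scatter of the measurement. Nothing shown here offers a measured property that accounts for this result.

As far as these compounds go, what remains open is how far this tolerance extends, since both groups at this position are saturated carbon rings without hydrogen-bond donors or acceptors, and an amine, a carboxylic acid or a ring containing oxygen would be a different kind of group. Plain cyclohexyl is also absent from the compounds shown, so the one step cannot separate the contribution of the larger ring from that of the trifluoromethyl group.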